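Cyano in place of methyl on the sulfonyl aryl ring

The compounds below may be only part of what the source reports. "The series", "measured", "known", "first", "only" and "open" are said of these compounds alone.

Compound 3 `Cc1ccc(S(=O)(=O)N2N=C(c3ccc(N4CCN(C)CC4)cc3)CC2c2ccc(N(C)C)cc2)cc1` stands lowest of the three measured compounds in a functional assay on NCI-H1975 cells (Homo sapiens) for inhibition, read by sulforhodamine B assay, tested at 10 uM; on this read-out higher numbers stand for more inhibition at the one concentration tested (going by the name of the read-out) and lower numbers for less inhibition; compound 3 gives 38.1%. Compound 1 `CN1CCN(c2ccc(C3=NN(C(=O)c4ccc(C(F)(F)F)cc4)C(c4ccc(N(C)C)cc4)C3)cc2)CC1` gives 93.2%, and compound 2 `CN1CCN(c2ccc(C3=NN(C(=O)/C=C/c4ccccc4)C(c4ccc(N(C)C)cc4)C3)cc2)CC1` gives 81%. The step of a number 55.1 percentage points lower from compound 1 to compound 3 (beyond the scatter) and the step of a number 42.9 percentage points lower from compound 2 to compound 3 (beyond the scatter) were both large, whereas the step of a number 12.2 percentage points lower from compound 1 to compound 2 (beyond the scatter) was modest.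

Compound 4 `CN1CCN(c2ccc(C3=NN(S(=O)(=O)c4ccc(C#N)cc4)C(c4ccc(N(C)C)cc4)C3)cc2)CC1` differs from compound 3 by cyano in place of methyl on an aromatic carbon. Among the measured compounds shown here, no measured step exchanges one substituent for another on the (4-methylphenyl)sulfonyl group; the two large steps concern the exchange of a carbonyl-linked group for the sulfonyl group, and compound 4 keeps the sulfonyl group. For the measured compounds named here, the only comparison of two different aryl groups on the same linker, a number 12.2 percentage points lower from compound 1 to compound 2 (beyond the scatter), was modest. For compound 4 the step expected is therefore a number 1.9 percentage points higher from compound 3 to compound 4 (within the scatter), not beyond the scatter in either direction. Compound 4 is estimated at 40%, with a range from 22% to 58%.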

Compound 4, a percentage reported as inhibition, at one concentration (the size of the read-out at that concentration, not a potency): 100%
Compound 4: middle estimate off by 60 percentage points, on the low side; the whole stated range lies below it.
By their numbers in this assay, from the lowest: compound 3; then compound 2; then compounds 1 and 4 (each within the scatter of the next).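

In this assay the substituent on the aryl ring of the sulfonyl group carries a large step, the step of a number 61.9 percentage points higher from compound 3 to compound 4 (beyond the scatter) arising from cyano in place of methyl, so the low value of compound 3 does not follow from the sulfonyl linker alone. With the 4-cyanophenyl group, the sulfonyl linker gives the step of a number 6.8 percentage points higher from compound 1 to compound 4 (within the scatter) against the carbonyl-linked 4-(trifluoromethyl)phenyl compound and the step of a number 19 percentage points higher from compound 2 to compound 4 (beyond the scatter) against the carbonyl-linked 2-phenylethenyl compound. No measurement at hand accounts for the size of the cyano step.

Open, on these data alone, is how other groups on this aryl carbon, such as an amine, a carboxylic acid or a methoxy group, would read on the sulfonyl series. Also open, as far as these compounds go, is whether 4-cyanophenyl on the carbonyl linker would read like compound 4, and a single-concentration read-out cannot separate compounds at this level by potency.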